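The source may hold more compounds than are shown below. What is called first, only, known or untested is meant among the compounds shown, and "the series" means these compounds.

Series notes. Compound 3 `O=C1CC(C(F)(F)F)CN1c1cnn2c1CN(C(=O)Nc1cc(F)c(F)c(F)c1)C(C1CC1)C2` holds the highest number among the three measured in a toxicity assay on HepG2 2.2.15 cells (Homo sapiens) for cytotoxicity, read by CellTiter-Glo; on this read-out lower numbers stand for higher toxicity in this test and higher numbers for lower toxicity in this test; compound 3 gives 115000 nM. Compound 2 `O=C1CC(Oc2ncc(F)cn2)CN1c1cnn2c1CN(C(=O)Nc1cc(F)c(F)c(F)c1)C(C1CC1)C2` gives 96200 nM, and compound 1 `O=C(Nc1cc(F)c(F)c(F)c1)N1Cc2c(-c3ccc(F)cc3F)cnn2CC1C1CC1` gives 32100 nM. The two steps into compound 3 differ in weight: a 3.6-fold higher number from compound 1 to compound 3 (0.55 log units; beyond the scatter), whereas a 1.2-fold higher number from compound 2 to compound 3 (0.08 log units; within the scatter).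

Compound 4 `Cc1cnc(C2CC(=O)N(c3cnn4c3CN(C(=O)Nc3cc(F)c(F)c(F)c3)C(C3CC3)C4)C2)s1` is the next variation at the same saturated ring carbon: 5-methyl-1,3-thiazol-2-yl in place of trifluoromethyl on a saturated ring carbon. Going by the values given here, the one step bearing on this position, from (5-fluoropyrimidin-2-yl)oxy to trifluoromethyl, stayed within the scatter, so a further swap at that carbon is expected to move little. For compound 4 the step of a 1.2-fold lower number from compound 3 to compound 4 (0.06 log units; within the scatter) is expected to stay within the scatter. Compound 4 is therefore estimated at 100000 nM, with a range of 40000 nM to 250000 nM.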

Compound 4, half-maximal cytotoxic concentration: 96200 nM
Beside the measured number, compound 4's estimate is 1.0-fold (0.02 log units) above it; measured number inside the range.
By their numbers in this assay, from the lowest: compound 1; then compounds 2, 4 and 3 (each within the scatter of the next).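

With 5-methyl-1,3-thiazol-2-yl on the saturated ring carbon, this assay gives (a 1.2-fold lower number from compound 3 to compound 4 (0.08 log units; within the scatter)) and (no change at the digits printed from compound 2 to compound 4 (within the scatter)), so three different groups at that carbon now lie within the scatter of one another. The step from 2,4-difluorophenyl on an aromatic carbon also stays beyond the scatter with this group (a 3.0-fold higher number from compound 1 to compound 4 (0.48 log units; beyond the scatter)). Nothing measured here accounts for these numbers.

Open, going by these compounds, is whether an amine or a carboxylic acid at the saturated ring carbon would stay in the same range. Also open, on these data alone, is how the bare 2-oxopyrrolidin-1-yl group would compare with compound 1.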